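Compound 3 to compound 4: ring swap on the side chain

The compounds below may be only part of what the source reports. "The series", "measured", "known", "first", "only" and "open" are said of these compounds alone.

Three analogues on the shared core have numbers in an assay for inhibition of RAC-alpha serine/threonine-protein kinase (Homo sapiens), read by HTRF, with a stated time of 1 h; a lower number here means a stronger inhibitor, a higher number a weaker inhibitor. Compound 1 `Cn1ncc(Cl)c1-c1cc(C(=O)N[C@@H]2CN[C@H](CCn3cncn3)C[C@H]2c2ccc(Cl)c(Cl)c2)oc1Cl` gives 4.47 nM; compound 2 `Cn1ncc(Cl)c1-c1cc(C(=O)N[C@@H]2CN[C@H](CC(=O)O)C[C@H]2c2ccc(Cl)c(Cl)c2)oc1Cl` gives 1.94 nM; compound 3 `Cn1ncc(Cl)c1-c1cc(C(=O)N[C@@H]2CN[C@H](CCN3CCC(O)CC3)C[C@H]2c2ccc(Cl)c(Cl)c2)oc1Cl` gives 5.99 nM. Compound 3 has the highest of the three numbers, but the gap a 1.3-fold higher number from compound 1 to compound 3 (0.13 log units; within the scatter) is within the scatter, while the gap a 3.1-fold higher number from compound 2 to compound 3 (0.49 log units; beyond the scatter) is beyond it and modest. The step of a 2.3-fold lower number from compound 1 to compound 2 (0.36 log units; beyond the scatter) is likewise modest.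

Compound 4 `Cn1ncc(Cl)c1-c1cc(C(=O)N[C@@H]2CN[C@H](CCN3CCCC3)C[C@H]2c2ccc(Cl)c(Cl)c2)oc1Cl` differs from compound 3 as pyrrolidin-1-yl in place of 4-hydroxypiperidin-1-yl on a saturated chain carbon, two bonds along the chain from a saturated ring carbon. Among the compounds with values here, no measured step exchanges one saturated ring for another at this position, so there is no direct precedent. The two steps that reach compound 3 show that varied groups on this chain, the (1H-1,2,4-triazol-1-yl)methyl of compound 1 and the (4-hydroxypiperidin-1-yl)methyl of compound 3, land within the scatter of each other, and only the carboxy of compound 2 stands apart. A change from compound 3 to compound 4 of no more than the scatter is therefore expected, with no preferred direction, as a 1.1-fold lower number from compound 3 to compound 4 (0.04 log units; within the scatter). Compound 4 is expected to give 5.5 nM in this assay. For compound 4 the range 2.5 nM to 12 nM is estimated.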

Compound 4, half-maximal inhibitory concentration: 6.41 nM
Beside the measured number, compound 4's estimate is 1.2-fold (0.07 log units) below it, within the range that was stated.
By their numbers in this assay, from the lowest: compound 2; then compounds 1, 3 and 4 (each within the scatter of the next).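

In this assay, the exchange of one saturated ring for another on this chain gives a 1.1-fold higher number from compound 3 to compound 4 (0.03 log units; within the scatter) even though pyrrolidin-1-yl has 5 heavy atoms and 0 hydrogen-bond donors, against 7 heavy atoms and 1 hydrogen-bond donor for 4-hydroxypiperidin-1-yl. With a 1.4-fold higher number from compound 1 to compound 4 (0.16 log units; within the scatter) as well, the pyrrolidin-1-yl, 4-hydroxypiperidin-1-yl and 1H-1,2,4-triazol-1-yl groups all lie within the scatter of one another at this position, whereas a 3.3-fold higher number from compound 2 to compound 4 (0.52 log units; beyond the scatter) keeps the carboxy of compound 2 apart from all three. No evidence is available that accounts for these results.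

The compounds shown leave open how a methyl ester or a primary amide in place of the carboxy would compare, and so whether the separation of compound 2 is specific to the carboxylic acid. They also leave open how an open-chain dimethylamino group, a morpholin-4-yl ring or a longer chain carrying the pyrrolidin-1-yl group would compare with the ring-bearing side chains of compound 3 and compound 4.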